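The source may report more compounds than this note shows. Statements on the series, on what has been measured and on what is new or still open speak of the compounds shown alone.

Of the compounds shown here, three have numbers so far in an assay on isolated protein for inhibition of ribosomal protein S6 kinase alpha-5 (Homo sapiens), read by mobility shift assay, tested at 30 uM; on this read-out higher numbers stand for more inhibition at the one concentration tested (going by the name of the read-out) and lower numbers for less inhibition. Compound 1 `Nc1c2c(=O)[nH]c(-c3ccccc3)cc2nn1-c1ccccc1` gives 13%. Compound 2 `Cc1cc2[nH]ncc2c(=O)[nH]1` gives 2%. Compound 3 `Cc1cc2nc(N)nc(N)c2c(=O)[nH]1` gives 6%, the second highest of the three numbers; its nearest neighbour is compound 2, whose number lies within the scatter of it, and its furthest is compound 1, whose number also lies within the scatter. Going by the values given here, none of the three therefore stands apart from the others on what has been measured, and no pair of them differs in a single place, so no step of known size is available for guidance.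

Compound 4 `Cc1nc(N)c2c(=O)[nH]c(C)cc2n1` has not yet been measured in this assay. It differs from compound 3 in one place: methyl in place of amino on an aromatic carbon. The change sits on an aromatic carbon of a six-membered aromatic ring with two nitrogen atoms, part of a fused system of two rings, meta to an amino group and meta and para to a fused ring. Among the compounds with values here, nothing among the measured compounds speaks for a large step in either direction, since all three numbers lie within the scatter of one another. The expected step of a number 1 percentage points lower from compound 3 to compound 4 (within the scatter) is none beyond the scatter. Compound 4 is therefore estimated at 5%, with a range from -5% to 16%.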

Compound 4, a percentage reported as inhibition, at one concentration (the size of the read-out at that concentration, not a potency): 0%
Compound 4: the middle estimate sits 5 percentage points above what was measured; the range from low to high includes it.
By their numbers in this assay, from the lowest: compounds 4, 2, 3 and 1 (each within the scatter of the next, the first and the last beyond it).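

In this assay, going by these compounds alone, the change of methyl in place of amino on this aromatic carbon, between two ring nitrogen atoms, gives a number 6 percentage points lower from compound 3 to compound 4 (within the scatter), and this is the first single-place comparison. At this position, then, the amino group, with its hydrogen-bond donor and acceptor, and the methyl group, with neither, cannot be told apart in this read-out at the one concentration tested. No measurement at hand bears on this result or offers a reason for it.

Still open, from the compounds shown here alone, is whether any other group on this carbon, such as a methoxy group, a hydroxyl group, a carboxylic acid or a longer alkyl chain, would give a step beyond the scatter, since one exchange does not describe the position as a whole. Going by these compounds, the part played by the amino group that compound 3 and compound 4 share, which stays in place across this step, is also open, as is whether a change at that second site would behave in the same way.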